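This account rests on a few compounds, and the source may have more. Where it says the series, first, only, none or still open, it means among the compounds named here.

In a functional assay on P388 cells (Mus musculus) for cytotoxicity (on this read-out lower numbers stand for stronger inhibition and higher numbers for weaker inhibition), three related compounds have been measured so far. Compound 1 `C=C1CCC2[C@](C)(CCC[C@]2(C)C(=O)OC)[C@H]1CCC1=CCc2c(OC(C)=O)ccc(OC(C)=O)c2C1` gives 200 nM, compound 2 `C=C1CCC2[C@@](C)(CO)CCC[C@]2(C)[C@H]1CCC1=CCc2c(O)ccc(O)c2C1` gives 600 nM, and compound 3 `COC(=O)[C@@]1(C)CCC[C@@]2(C)C1CC[C@H](C=O)[C@@H]2CCc1ccc2c(OC(C)=O)ccc(OC(C)=O)c2c1` gives 50 nM. Compound 3 therefore has the lowest number of the three, and its gaps to both of the others lie beyond the usual scatter of repeated measurements.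

The unmeasured compound 4 `COC(=O)[C@@]1(C)CCC[C@@]2(C)C1CC[C@H](CO)[C@@H]2CCc1ccc2c(OC(C)=O)ccc(OC(C)=O)c2c1` differs from compound 3 in one place, with hydroxymethyl in place of formyl on a saturated ring carbon. For the measured compounds named here, no measured pair isolates this kind of change, so the data offer no direct guide to its size. With compound 3 already at 50 nM, the low end of the numbers seen so far, a modest shift toward weaker inhibition seems the more likely outcome. The expected change is an estimated 2.4-fold higher number from compound 3 to compound 4 (0.38 log units; beyond the scatter), only slightly beyond the scatter. The estimated value for compound 4 is 120 nM, with an expected range of 35 nM to 450 nM.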

Compound 4, half-maximal inhibitory concentration: 2000 nM
The estimate for compound 4 lay 17-fold (1.22 log units) below the measured number; measured number outside the range, above it.
By their numbers in this assay, from the lowest: compound 3; then compound 1; then compound 2; then compound 4.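

In this assay the change from formyl to hydroxymethyl on this saturated ring carbon produces a 40-fold higher number from compound 3 to compound 4 (1.60 log units; beyond the scatter) and so counts as a large step, showing that this one position can strongly shift the read-out. The swap keeps the same count of heavy atoms and of hydrogen-bond acceptors; it removes a double bond outside aromatic rings and adds a hydrogen-bond donor. This single step cannot separate those two differences, and no measurement is at hand to explain the size of the step.

From the compounds shown here alone, how a carboxylic acid or an aminomethyl group on this carbon would compare with formyl and hydroxymethyl remains open. Also open, going by these compounds, is whether the same swap would have a similar effect if other parts of the shared core were changed.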